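A few compounds are considered here, and "the series" means these few. Any claim that something is new, unique, unknown or untested is made for them only; others in the source may bear on it.

Measured in a physicochemical assay for solubility, in phosphate buffer, with a stated time of 5 h, at pH 7.4; a higher number here means a more soluble compound, a lower number a less soluble compound:
- compound 1 `Cc1c(Cc2ccc(C(F)(F)F)nc2)c[nH]c1C(=O)NC(C)c1cnn(C)c1`: 49 ug/mL
- compound 2 `Cc1cc(C(C)NC(=O)c2[nH]cc(Cc3ccc(C(F)(F)F)nc3)c2C)no1`: 5.9 ug/mL

Compound 2 holds the lower of the two numbers. The next compound, 3 in the series, is written here as compound 3 `Cc1c(Cc2ccc(C(F)(F)F)nc2)c[nH]c1C(=O)NC(C)c1cn[nH]c1` and is not yet measured. The change from compound 2 is 1H-pyrazol-4-yl in place of 5-methyl-1,2-oxazol-3-yl on a saturated chain carbon bound to an amide-type nitrogen and a saturated chain carbon: 1H-pyrazol-4-yl in place of 5-methyl-1,2-oxazol-3-yl.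

Going by the values given here, only one measured step bears on this: an 8.3-fold lower number from compound 1 to compound 2 (0.92 log units; beyond the scatter), modest but beyond the scatter, where 5-methyl-1,2-oxazol-3-yl replaced 1-methyl-1H-pyrazol-4-yl. Among the compounds with values here, compound 3 reverses that replacement, except that it lacks the methyl of compound 1, and no measured step covers that difference. A rise of similar size in this assay is therefore expected, with an estimated 7.6-fold higher number from compound 2 to compound 3 (0.88 log units; beyond the scatter). Compound 3 is expected at 45 ug/mL, with an estimated range of 15 ug/mL to 130 ug/mL.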

Compound 3, solubility: 23 ug/mL
For compound 3 the middle estimate is 2.0-fold (0.29 log units) above the measured one, within the range that was stated.
By their numbers in this assay, from the lowest: compound 2; then compound 3; then compound 1.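

In this assay, the step to 1H-pyrazol-4-yl at this place is a 3.9-fold higher number from compound 2 to compound 3 (0.59 log units; beyond the scatter), so this unsubstituted ring also reads above 5-methyl-1,2-oxazol-3-yl, as the 1-methyl-1H-pyrazol-4-yl of compound 1 already did. The methyl on the aromatic nitrogen now has a step of its own, with hydrogen in its place giving a 2.1-fold lower number from compound 1 to compound 3 (0.33 log units; beyond the scatter), so the methylated ring holds the higher number of the two and that methyl is not neutral here. Nothing at hand accounts for either step.

The step from the 5-methyl-1,2-oxazol-3-yl also removes a ring methyl, so the effects of the ring and of that methyl remain unseparated. Also open, from the compounds shown here alone, is how a longer chain or a hydroxyethyl group on the same aromatic nitrogen, or an amine on the ring, would read in this assay.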